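A few compounds are considered here, and "the series" means these few. Any claim that something is new, unique, unknown or untested is made for them only; others in the source may bear on it.

The series shares one core, and the group attached to its carbonyl carbon is what changes. Compound 1 `COc1ccc2[nH]c(C(=O)N[C@H](CCCNC(=N)N)C(=O)NCc3ccc(C(F)(F)F)cc3)cc2c1` gives 78 nM in a functional assay on HEK293 cells for antagonist activity at melanin-concentrating hormone receptor 1 (Homo sapiens); on this read-out lower numbers stand for stronger inhibition and higher numbers for weaker inhibition. Compound 2 `N=C(N)NCCC[C@@H](NC(=O)c1cc2ccccc2cn1)C(=O)NCc1ccc(C(F)(F)F)cc1` gives 1810 nM in the same assay, and compound 3 `COc1cccc2cc(C(=O)N[C@H](CCCNC(=N)N)C(=O)NCc3ccc(C(F)(F)F)cc3)oc12` gives 622 nM. Compound 3 thus stands second highest of the three, nearer to compound 2 than to compound 1; the steps are an 8.0-fold higher number from compound 1 to compound 3 (0.90 log units; beyond the scatter), a 23-fold higher number from compound 1 to compound 2 (1.37 log units; beyond the scatter) and a 2.9-fold lower number from compound 2 to compound 3 (0.46 log units; beyond the scatter). Compound 4 `N=C(N)NCCC[C@@H](NC(=O)c1csc2ccccc12)C(=O)NCc1ccc(C(F)(F)F)cc1` carries the change (1-benzothiophen-3-yl in place of 7-methoxy-1-benzofuran-2-yl on a carbonyl carbon). For the measured compounds named here, no measured step swaps these two groups, but every step in this set, which each exchange the whole group on the carbonyl carbon, moved the number beyond the scatter, and the departure from compound 1 in either direction raised it. A modest rise from compound 3 is therefore expected for compound 4, so that the step of a 2.4-fold higher number from compound 3 to compound 4 (0.38 log units; beyond the scatter) is estimated. Compound 4 is expected to give about 1500 nM, with a range from 400 nM to 6000 nM.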

Compound 4, half-maximal inhibitory concentration: 952 nM
For compound 4 the middle estimate is 1.6-fold (0.20 log units) above the measured one; the measured number falls inside the stated range.
By their numbers in this assay, from the lowest: compound 1; then compounds 3, 4 and 2 (each within the scatter of the next, the first and the last beyond it).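

In this assay, the steps of a 1.5-fold higher number from compound 3 to compound 4 (0.18 log units; within the scatter) and a 1.9-fold lower number from compound 2 to compound 4 (0.28 log units; within the scatter) show that the 1-benzothiophen-3-yl group on this carbonyl carbon cannot be told apart from either the 7-methoxy-1-benzofuran-2-yl or the isoquinolin-3-yl group, although those two groups are separated from each other beyond the scatter. Exchanging the whole group at this place therefore does not always move the number beyond the scatter, even when the entering group has fewer heavy atoms and hydrogen-bond acceptors than the one it replaces. Compound 1 still stands apart, with a 12-fold higher number from compound 1 to compound 4 (1.09 log units; beyond the scatter) adding a third step beyond the scatter from its 5-methoxy-1H-indol-2-yl group.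

Going by these compounds, it remains open whether a methoxy group, an amine or a carboxylic acid on the 1-benzothiophen-3-yl group would bring the number closer to that of compound 1. Nothing available here explains any of these differences.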